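Carbamate in place of aryl amide: cytotoxicity on Vero cells

The source may report more compounds than this note shows. Statements on the series, on what has been measured and on what is new or still open speak of the compounds shown alone.

Compound 1 `CCN(CC)c1cc2[nH]c(C3CCCCC3)nc2cc1NC(=O)c1cnccn1`: > 100 ug/mL
Compound 2 `CCN(CC)c1cc2[nH]c(C3CCCCC3)nc2cc1NC(=O)c1ccc(N(C)C)cc1`: "not determined" (no result reported)

In an ADME assay on Vero cells (Chlorocebus sabaeus) for cytotoxicity, read by resazurin assay, with a stated time of 3 days (a higher number here means a weaker inhibitor, a lower number a stronger inhibitor), compound 1 gives > 100 ug/mL, which is a limit of the assay and not a number (the limit of > 100 ug/mL in this assay, at which 1 of the 2 values shown sits). For compound 2 the result in this assay is "not determined" (no result reported), so compound 2 stands on no number at all. Compound 3 `CCN(CC)c1cc2[nH]c(C3CCCCC3)nc2cc1NC(=O)OCC(F)(F)F` differs from compound 2 by 2,2,2-trifluoroethoxy in place of 4-(dimethylamino)phenyl on a carbonyl carbon. Going by the values given here, with no measured step to lean on, a step beyond the usual scatter is not expected in either direction. Compound 3 is estimated to give 100 ug/mL in this assay, in the range 40 ug/mL to 200 ug/mL.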

Compound 3, half-maximal inhibitory concentration: > 100 ug/mL
Compound 3 was reported as a limit; the forecaster's own chance of this, stated with the estimate: 70%; the middle value lies on the limit itself.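

In this assay, compound 1 and compound 3 both stand at a limit and not at a number, so no step between them can be read: the limit of > 100 ug/mL in this assay, at which 2 of the 3 values shown sit.

The compounds shown leave open whether pyrazin-2-yl and 2,2,2-trifluoroethoxy on the carbonyl carbon differ at all in this assay.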